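A few compounds are considered here, and "the series" means these few. Any claim that something is new, unique, unknown or untested is made for them only; others in the source may bear on it.

In a functional assay on HeLa cells (Homo sapiens) for antiproliferative activity, read by MTT assay, with a stated time of 48 h (on this read-out lower numbers stand for stronger inhibition and higher numbers for weaker inhibition), compound 1 (`Cc1ccc(-c2nn(-c3ccccc3)cc2C(Nc2nc3cc(C)c(C)cc3s2)c2c(O)ccc3ccccc23)cc1`) gives 17800 nM and compound 2 (`COc1cccc(-c2nn(-c3ccccc3)cc2C(Nc2nc3ccccc3s2)c2c(O)ccc3ccccc23)c1`) gives 14900 nM, so these two values lie within the scatter of each other. Compound 3 (`Oc1ccc2ccccc2c1C(Nc1nc2ccccc2s1)c1cn(-c2ccccc2)nc1-c1cccc(Cl)c1`) carries chloro in place of methoxy on an aromatic carbon, which turns 3-methoxyphenyl into 3-chlorophenyl. For the measured compounds named here, no measured pair shows this change, so no shift beyond the scatter is expected in this assay in either direction. The estimated step (a 1.1-fold lower number from compound 2 to compound 3 (0.03 log units; within the scatter)) is therefore small. Compound 3 is expected at 14000 nM within an estimated range from 6000 nM to 32000 nM in this read-out.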

Compound 3, half-maximal inhibitory concentration: 6830 nM
For compound 3 the middle estimate is 2.0-fold (0.31 log units) above the measured one; measured number inside the range.
By their numbers in this assay, from the lowest: compound 3; then compounds 2 and 1 (each within the scatter of the next).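

Chloro in place of methoxy on this aromatic carbon gives a 2.2-fold lower number from compound 2 to compound 3 (0.34 log units; beyond the scatter) in this assay, so the group held here can shift the number beyond the scatter. Compound 1 and compound 2 differ in more than one place and could not show this. Nothing available explains the step. Going by these compounds, whether an amino group, a nitrile or a trifluoromethyl group on this carbon would lower the number further remains open. So does whether 3-chlorophenyl would give a similar step alongside the two methyl groups of compound 1.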